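One More Methyl on the Ring Side Chain

The source may report more compounds than this note shows. Statements on the series, on what has been measured and on what is new or still open speak of the compounds shown alone.

Compound 3 `CC(C)=CCC(=O)C1(O)C(O)=C(CC(C)C)C(=O)C1CC=C(C)C` gives 2.87 in a physicochemical assay for lipophilicity, measured as octanol-water partition (a lower number here means a more polar compound, a higher number a more lipophilic compound), the second highest of the three numbers. Compound 1 `CC(C)=CCC1=C(O)C(C(=O)C(C)C(C)C)=C(O)[C@](O)(CC=C(C)C)C1=O` gives 3, within the scatter of compound 3. Among the compounds with values here, compound 2 `CC(C)=CCC(=O)C1(O)C(O)=C(C(C)C)C(=O)C1CC=C(C)C` gives 2.05, and the step of a number 0.82 log units higher from compound 2 to compound 3 (beyond the scatter) is the only measured change that bears on what follows. Compound 4 `CC(C)=CCC(=O)C1(O)C(O)=C(C(C)C(C)C)C(=O)C1CC=C(C)C` differs from compound 3 by methyl in place of hydrogen on a saturated chain carbon bound to a double-bonded ring carbon and a saturated chain carbon. Because that added methyl repeats the kind of growth seen in a number 0.82 log units higher from compound 2 to compound 3 (beyond the scatter), a rise in this assay is expected, though with one guide only, a somewhat smaller rise seems the safer expectation. Compound 4 is therefore expected at 3.4, between 3 and 3.8. The expected step is a number 0.53 log units higher from compound 3 to compound 4 (beyond the scatter).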

Compound 4, partition coefficient: 2.53
For compound 4 the middle estimate is 0.87 log units above the measured one; the measured number lies below the stated range.
By their numbers in this assay, from the lowest: compound 2; then compound 4; then compounds 3 and 1 (each within the scatter of the next).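

In this assay, this position does not reward every added carbon: methyl in place of hydrogen on this saturated chain carbon gives a number 0.34 log units lower from compound 3 to compound 4 (beyond the scatter), reversing the direction of the earlier isobutyl change. The 1,2-dimethylpropyl side chain still keeps part of the gain over isopropyl, with a number 0.48 log units higher from compound 2 to compound 4 (beyond the scatter), so the side chains shown do not follow a single trend with size. Nothing available explains this turn. Going by these compounds, whether a longer unbranched chain would follow isobutyl or 1,2-dimethylpropyl remains open. So does the result of an amine on this side chain.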